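A few compounds are considered here, and "the series" means these few. Any claim that something is new, unique, unknown or untested is made for them only; others in the source may bear on it.

In a functional assay on the whole organism (strain albino) with Mus musculus as the target, with a stated time of 0.5 h (on this read-out higher numbers stand for an effect only at larger amounts of compound and lower numbers for an effect already at smaller amounts), compound 3 `CC(=O)N1N=C(Nc2nc3ccccc3s2)CC1c1ccc(Cl)cc1` has no number to start from: its entry reads "not determined" (no result reported). Compound 4 `CC(=O)N1N=C(Nc2nc3ccc(C)cc3s2)CC1c1ccc(Cl)cc1` differs from it by a single change, (methyl in place of hydrogen on an aromatic carbon), methyl in place of hydrogen on an aromatic carbon. Among the measured compounds shown here, no measured step covers this change. The closest evidence comes from compound 1 `COc1ccc(C2CC(Nc3nc4ccc(C)cc4s3)=NN2C(C)=O)cc1`, at 39.4 umol/kg, and compound 2 `COc1ccc(C2CC(Nc3nc4ccc(C)cc4s3)=NN2C(C)=O)cc1O`, at 75.6 umol/kg. Both carry the same methyl but lack the chloro group of compound 4. For the measured compounds named here, the only measured step, a 1.9-fold higher number from compound 1 to compound 2 (0.28 log units; within the scatter), puts hydroxy in place of hydrogen and stays within the scatter, so it bears on the methyl change only indirectly. With no number for compound 3, no size or direction can be expected for the step itself. The level of the estimate therefore rests on the two methyl-bearing compounds, and the range is kept wide for the untested chloro group. Compound 4 is expected in this assay at about 50 umol/kg, with an estimated range from 18 umol/kg to 130 umol/kg.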

Compound 4, dose for half-maximal effect: 27.5 umol/kg
Beside the measured number, compound 4's estimate is 1.8-fold (0.26 log units) above it; measured number inside the range.
By their numbers in this assay, from the lowest: compounds 4, 1 and 2 (each within the scatter of the next, the first and the last beyond it).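

In this assay the chloro group now stands on the methyl-bearing core, and chloro in place of methoxy on an aromatic carbon gives a 1.4-fold lower number from compound 1 to compound 4 (0.16 log units; within the scatter) and so no change beyond the scatter. The exchange of 3-hydroxy-4-methoxyphenyl for 4-chlorophenyl on a saturated ring carbon reaches further, with a 2.7-fold lower number from compound 2 to compound 4 (0.44 log units; beyond the scatter) as a modest step beyond the scatter. Nothing at hand accounts for either step.

As far as these compounds go, the step from compound 3 to compound 4 cannot be read, so what the methyl in place of hydrogen does on its own remains open. Also open, from the compounds shown here alone, is how an amine, a carboxylic acid or a longer chain would fare in place of that methyl on the same aromatic carbon.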